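This account rests on a few compounds, and the source may have more. Where it says the series, first, only, none or still open, it means among the compounds named here.

Measured so far in a functional assay on MDA-MB-468 cells (Homo sapiens) for antiproliferative activity, read by MTT assay, with a stated time of 72 h; on this read-out higher numbers stand for weaker inhibition and lower numbers for stronger inhibition:
compound 1 `O=C(Nc1ccc(Cl)c(-c2nnc3c(Cl)cccn23)c1)c1ccc(C(F)(F)F)cc1F` — 22300 nM
compound 2 `O=C(Nc1ccc(Cl)c(-c2nnc3c(Cl)cccn23)c1)c1ccccc1` — a limit, > 100000 nM
compound 3 `Cc1nc(C(=O)Nc2ccc(Cl)c(-c3nnc4c(Cl)cccn34)c2)cs1` — a limit, > 100000 nM

Compound 3 stands at the assay limit, as does compound 2; two of the three values sit at the limit of > 100000 nM in this assay, at which 2 of the 3 values shown sit. Within the data shown here, compound 1 is the only compound to give a number. The step that the two limits leave unreadable from compound 2 to compound 3 cannot be read against these limits. Compound 4 `Cc1cc(Cl)ccc1C(=O)Nc1ccc(Cl)c(-c2nnc3c(Cl)cccn23)c1` differs from compound 3 by 4-chloro-2-methylphenyl in place of 2-methyl-1,3-thiazol-4-yl on a carbonyl carbon. Among the measured compounds shown here, no measured step speaks directly to this change; the only guide is that compound 1, carrying a substituted phenyl on the carbonyl carbon, gives 22300 nM. Compound 2, with plain phenyl, gives only a limit, > 100000 nM. A move back toward a readable number is therefore expected, of size an at least 2.5-fold lower number from compound 3 to compound 4 (0.39 log units; beyond the scatter). Compound 4 is estimated at 40000 nM, between 10000 nM and 150000 nM.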

Compound 4, half-maximal inhibitory concentration: 34300 nM
Compound 4: the middle estimate sits 1.2-fold (0.07 log units) above what was measured; measured number inside the range.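

In this assay, 4-chloro-2-methylphenyl on the carbonyl carbon gives a readable value where 2-methyl-1,3-thiazol-4-yl does not, with an at least 2.9-fold lower number from compound 3 to compound 4 (0.46 log units; beyond the scatter). Set against plain phenyl, the same group gives an at least 2.9-fold lower number from compound 2 to compound 4 (0.46 log units; beyond the scatter), so this position can leave the assay limit with a phenyl that carries substituents. Both steps give only a minimum size, since their starting values are limits and not numbers: the limit of > 100000 nM in this assay, at which 2 of the 4 values shown sit.

Going by these compounds, whether the chloro or the methyl alone would give the same step remains open. So does the effect of an amine or a carboxylic acid on this phenyl ring.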